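An acetamide replaces two methyl groups on compound 1

The compounds below may be only part of what the source reports. "The series", "measured", "known", "first", "only" and "open" are said of these compounds alone.

Compound 1 `Cc1nc(-c2ccccc2)c(C(=O)N2CCN(c3cccc(C)c3C)CC2)o1` is tested in a functional assay on HL-60 cells (Homo sapiens) for inhibition, read by MTT assay, with a stated time of 72 h (on this read-out higher numbers stand for weaker inhibition and lower numbers for stronger inhibition), where compound 1 gives 35 nM. Of the two numbers shown, compound 1 has the lower; its nearest neighbour is compound 3 `CCc1nc(-c2ccccc2Cl)c(C(=O)N2CCN(c3cccc(Cl)c3)CC2)o1`, which in this assay gives 98.9 nM, a gap beyond the scatter. Compound 2 `Cc1ccc(C)c(N2CCN(C(=O)c3oc(C)nc3-c3ccccc3Cl)CC2)c1` reaches only a limit in this assay, > 1000 nM. That is the limit of > 1000 nM in this assay, at which 1 of the 3 values shown sits. Going by the values given here, the unmeasured compound 4 `CC(=O)Nc1cccc(N2CCN(C(=O)c3oc(C)nc3-c3ccccc3)CC2)c1` differs from compound 1 in one place: 3-acetamidophenyl in place of 2,3-dimethylphenyl on an amine nitrogen in a ring No measured pair mirrors this change, so its size is uncertain. The step of a 4.3-fold higher number from compound 1 to compound 4 (0.63 log units; beyond the scatter) is expected to be a modest weakening, somewhat beyond the scatter. Compound 4 is therefore estimated to give about 150 nM, within a range of 40 nM to 600 nM.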

Compound 4, half-maximal inhibitory concentration: 329 nM
Compound 4: middle estimate off by 2.2-fold (0.34 log units), on the low side; the range from low to high includes it.
By their numbers in this assay, from the lowest: compound 1; then compound 3; then compound 4. At a limit, above all of these: compound 2.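

The position on the amine nitrogen in the ring is sensitive to change: 3-acetamidophenyl in place of 2,3-dimethylphenyl gives a 9.4-fold higher number from compound 1 to compound 4 (0.97 log units; beyond the scatter) in this assay. This is the only single-place step shown, and the first measure of how much this position matters. Nothing shown bears on the reason for this step.

From the compounds shown here alone, the change removes both methyl groups and adds the acetamide, so their separate contributions stay open. Also open, going by these compounds, is how a simple amine or a carboxylic acid would fare in this position.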